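Amide tail variation in a dihydroxyheptanoic acid series

The compounds below may be only part of what the source reports. "The series", "measured", "known", "first", "only" and "open" are said of these compounds alone.

Measured compounds:
compound 1 `COc1ccc(CNC(=O)c2nc(-c3ccc(F)cc3)n(CC[C@@H](O)C[C@@H](O)CC(=O)O)c2C2CC2)cc1F` — 3.7 nM
compound 2 `CC(C)c1c(C(=O)NCc2ccccc2)nc(-c2ccc(F)cc2)n1CC[C@@H](O)C[C@@H](O)CC(=O)O` — 7.9 nM

Both were tested in an assay on microsomes from liver for inhibition of 3-hydroxy-3-methylglutaryl-coenzyme A reductase (Rattus norvegicus), read by scintillation counting, with stated times of 0.5 h and 0.75 h; on this read-out higher numbers stand for weaker inhibition and lower numbers for stronger inhibition. Compound 1 holds the lowest of the two numbers; compound 2 sits higher by a gap beyond the usual scatter. Compound 3 `CN(C)S(=O)(=O)c1ccc(CNC(=O)c2nc(-c3ccc(F)cc3)n(CC[C@@H](O)C[C@@H](O)CC(=O)O)c2C2CC2)cc1` awaits measurement. It differs from compound 1 by 4-(dimethylsulfamoyl)phenyl in place of 3-fluoro-4-methoxyphenyl on a saturated chain carbon bound to an amide-type nitrogen. Among the measured compounds shown here, no measured pair covers this change, so its effect is unknown. A modest step toward a higher number is expected, a 1.6-fold higher number from compound 1 to compound 3 (0.21 log units; within the scatter), likely not far beyond the scatter. Compound 3 is therefore estimated at 6 nM, with a range of 2 nM to 18 nM.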

Compound 3, half-maximal inhibitory concentration: 4.9 nM
Estimate against measurement, compound 3: 1.2-fold (0.09 log units) above; the range from low to high includes it.
By their numbers in this assay, from the lowest: compounds 1, 3 and 2 (each within the scatter of the next, the first and the last beyond it).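

On a saturated chain carbon bound to an amide-type nitrogen, 4-(dimethylsulfamoyl)phenyl can replace 3-fluoro-4-methoxyphenyl: this assay shows a 1.3-fold higher number from compound 1 to compound 3 (0.12 log units; within the scatter) and so does not separate the two compounds. The entering group has 12 heavy atoms against 9 and 2 hydrogen-bond acceptors against 1, yet the two numbers remain within the scatter. No measured evidence bears on this result. Open, going by these compounds, is whether a cyclohexyl group or a plain methyl group at this place, with no aromatic ring, would keep the number in this range. On these data alone, a longer chain carrying the phenyl ring also remains open.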